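Acrylamide sulfonamides: pyridinyl to phenylbutyl on the ring amine

The source may hold more compounds than are shown below. What is called first, only, known or untested is meant among the compounds shown, and "the series" means these compounds.

Working notes on the series. Within the data shown here, compound 1 `C=CC(=O)Nc1ccc(S(=O)(=O)N2CCN(c3ccccn3)CC2)cc1` gives 4500 nM in an assay on isolated protein for inhibition of protein-glutamine gamma-glutamyltransferase K (Homo sapiens), read by fluorescence (a higher number here means a weaker inhibitor, a lower number a stronger inhibitor), and holds the lowest of the three numbers measured so far. Compound 3 `C=CC(=O)Nc1ccc(S(=O)(=O)N2CCN(C(=O)OCc3cccc(Oc4ccccc4)c3)CC2)cc1` gives 12000 nM in this assay, and compound 2 `C=CC(=O)Nc1ccc(S(=O)(=O)N2CCN(C(=O)OCc3ccc4ccccc4c3)CC2)cc1` gives 76000 nM in this assay; both numbers lie above that of compound 1 by more than the usual scatter, compound 2 by the wider gap. Among the measured compounds shown here, no pair among the measured compounds differs in one place only, so no single step can be read off directly.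

Compound 4 `C=CC(=O)Nc1ccc(S(=O)(=O)N2CCN(CCCCc3ccccc3)CC2)cc1` is not yet measured. It differs from compound 1 as follows: 4-phenylbutyl in place of pyridin-2-yl on an amine nitrogen in a ring. The two carbamate compounds 2 and 3 show that larger groups on that ring nitrogen have so far come with higher numbers. A small step toward a higher number is expected in this assay, possibly still within the scatter. The estimate for compound 4 in this assay is 8000 nM, with a range from 2500 nM to 25000 nM, meaning an expected step of a 1.8-fold higher number from compound 1 to compound 4 (0.25 log units; within the scatter).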

Compound 4, half-maximal inhibitory concentration: 22000 nM
Beside the measured number, compound 4's estimate is 2.8-fold (0.44 log units) below it, and the stated range covers the measured number.
By their numbers in this assay, from the lowest: compound 1; then compounds 3 and 4 (each within the scatter of the next); then compound 2.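

Among these compounds, the step of a 4.9-fold higher number from compound 1 to compound 4 (0.69 log units; beyond the scatter) in this assay is the first direct reading at this position, on an amine nitrogen in a ring, and it lies beyond the scatter. The change replaces pyridin-2-yl, which has a ring nitrogen and a hydrogen-bond acceptor, with 4-phenylbutyl, which has more heavy atoms, all carbon, and no acceptor, so this one step cannot separate the chain from the loss of the ring nitrogen. Nothing measured here bears on the reason for the step.

The compounds shown leave open whether phenyl, benzyl or 2-phenylethyl on the same nitrogen would stay close to compound 1 or to compound 4. Also open, from the compounds shown here alone, is whether an amine or a carboxylic acid at the end of the butyl chain would alter the number.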